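Thioether series on the shared core: compound 4 outlook

The source may report more compounds than this note shows. Statements on the series, on what has been measured and on what is new or still open speak of the compounds shown alone.

Measured so far in an assay on isolated protein for binding affinity to Equilibrative nucleoside transporter 1 (Homo sapiens); on this read-out lower numbers stand for stronger inhibition and higher numbers for weaker inhibition:
- compound 1 `OC[C@H]1O[C@@H](n2cnc3c(NCc4ccco4)ncnc32)[C@H](O)[C@@H]1O`: 36300 nM
- compound 2 `OC[C@H]1O[C@@H](n2cnc3c(SC4CCCCC4)ncnc32)[C@H](O)[C@@H]1O`: 6310 nM
- compound 3 `OC[C@H]1O[C@@H](n2cnc3c(CSc4cccc(Cl)c4)ncnc32)[C@H](O)[C@@H]1O`: 282 nM

Compound 3 gives the lowest number of the three. Against compound 2 the step is a 22-fold lower number from compound 2 to compound 3 (1.35 log units; beyond the scatter), and against compound 1 it is a 130-fold lower number from compound 1 to compound 3 (2.11 log units; beyond the scatter); both steps replace a non-aromatic or heteroaromatic group with the (3-chlorophenyl)sulfanylmethyl group, and both lie beyond the scatter. The step of a 5.8-fold lower number from compound 1 to compound 2 (0.76 log units; beyond the scatter) is the smaller one.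

Compound 4 `OC[C@H]1O[C@@H](n2cnc3c(CSc4ccc(I)cc4)ncnc32)[C@H](O)[C@@H]1O` differs from compound 3 by 4-iodophenyl in place of 3-chlorophenyl on a sulfur. Within the data shown here, none of the measured steps changes only the halogen or its position on an aromatic ring, so no step bears directly on this change; the steps to compound 3 show only that an aryl thioether at this place is favourable, and that part is kept. The step from compound 3 to compound 4 in this assay is therefore expected to be small, a 1.1-fold lower number from compound 3 to compound 4 (0.05 log units; within the scatter), with no direction beyond the scatter called for. Compound 4 is estimated at 250 nM, within 80 nM to 900 nM.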

Compound 4, half-maximal inhibitory concentration: 69.2 nM
Compound 4: the middle estimate sits 3.6-fold (0.56 log units) above what was measured; the measured number lies below the stated range.
By their numbers in this assay, from the lowest: compound 4; then compound 3; then compound 2; then compound 1.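

In this assay the aryl ring on the sulfur proves to be a working part of the thioether and not just a carrier: a 4.1-fold lower number from compound 3 to compound 4 (0.61 log units; beyond the scatter) with 4-iodophenyl in place of 3-chlorophenyl, so a change confined to that ring moves the number beyond the scatter. The gain carries through the wider replacements on the shared core, with a 91-fold lower number from compound 2 to compound 4 (1.96 log units; beyond the scatter) against the cyclohexylsulfanyl group and a 520-fold lower number from compound 1 to compound 4 (2.72 log units; beyond the scatter) against the ((furan-2-yl)methyl)amino group. No evidence is available that accounts for the gain.

The step changes the halogen and its place on the ring at once, and the two stay unseparated; 4-chlorophenyl and 3-iodophenyl would part them. Also open, on these data alone, is how a plain phenyl, or a phenyl carrying an amine or a carboxylic acid, would read on this sulfur.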